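Compound 4 and the chain on the aromatic oxygen

This account rests on a few compounds, and the source may have more. Where it says the series, first, only, none or still open, it means among the compounds named here.

Measured in a functional assay on Ishikawa cells (Homo sapiens) for antiproliferative activity, read by CCK-8 assay, with a stated time of 48 h; a lower number here means a stronger inhibitor, a higher number a weaker inhibitor:
Compound 1 `O=C(/C=C/CNCCOc1ccc(Oc2c(-c3ccc(F)cc3)sc3cc(O)ccc23)cc1)N1CCCC1`: 11300 nM
Compound 2 `C=CC(=O)NCCOc1ccc(Oc2c(-c3ccc(F)cc3)sc3cc(O)ccc23)cc1`: > 25000 nM (a limit of the assay)
Compound 3 `C/C=C/C(=O)N1CC(Oc2ccc(Oc3c(-c4ccc(F)cc4)sc4cc(O)ccc34)cc2)C1`: 9400 nM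

Compound 3 at 9400 nM and compound 1 at 11300 nM lie within the scatter of each other. Compound 2 reports only a limit, > 25000 nM.

The next compound, compound 4 `CN(C)C(=O)/C=C/CNCCOc1ccc(Oc2c(-c3ccc(F)cc3)sc3cc(O)ccc23)cc1`, differs from compound 3 on an oxygen on an aromatic ring: 2-((3-(dimethylcarbamoyl)prop-2-en-1-yl)amino)ethyl in place of 1-((prop-1-en-1-yl)carbonyl)azetidin-3-yl on an oxygen on an aromatic ring. The measured steps bearing on this change are an at least 2.2-fold higher number from compound 1 to compound 2 (0.34 log units; beyond the scatter) and an at least 2.6-fold lower number from compound 2 to compound 3 (0.42 log units; beyond the scatter). Both run through the limit of compound 2, so each gives only a minimum size. Compound 4 has no ring in its 2-((3-(dimethylcarbamoyl)prop-2-en-1-yl)amino)ethyl group, yet compound 1 at 11300 nM shows that a value near that of compound 3 is reached without the 1-((prop-1-en-1-yl)carbonyl)azetidin-3-yl group. No change beyond the scatter is therefore expected in this assay, the expected step being a 1.2-fold higher number from compound 3 to compound 4 (0.07 log units; within the scatter). Compound 4 is estimated at 11000 nM, with an expected range of 5000 nM to 24000 nM.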

Compound 4, half-maximal inhibitory concentration: 11900 nM
For compound 4 the middle estimate is 1.1-fold (0.03 log units) below the measured one, within the range that was stated.
By their numbers in this assay, from the lowest: compounds 3, 1 and 4 (each within the scatter of the next). At a limit, above all of these: compound 2.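

In this assay, 2-((3-(dimethylcarbamoyl)prop-2-en-1-yl)amino)ethyl in place of 1-((prop-1-en-1-yl)carbonyl)azetidin-3-yl gives a 1.3-fold higher number from compound 3 to compound 4 (0.10 log units; within the scatter), so on this oxygen on an aromatic ring a group with no ring matches the azetidine group within the scatter. On the carbonyl carbon, dimethylamino in place of pyrrolidin-1-yl gives a 1.1-fold higher number from compound 1 to compound 4 (0.02 log units; within the scatter), while on the amine nitrogen, 3-(dimethylcarbamoyl)prop-2-en-1-yl in place of vinylcarbonyl gives an at least 2.1-fold lower number from compound 2 to compound 4 (0.32 log units; beyond the scatter). That last step has only a minimum size, as compound 2 reports only a limit: the limit of > 25000 nM in this assay, at which 1 of the 4 values shown sits.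

The compounds shown leave open whether morpholin-4-yl on the carbonyl carbon would stay within the scatter of these values. They also leave open how a longer chain in place of the ethyl on the aromatic oxygen would read in this assay.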